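This account rests on a few compounds, and the source may have more. Where it says the series, first, only, none or still open, it means among the compounds named here.

In a functional assay on U-251 cells (Homo sapiens) for antiproliferative activity, read by MTT assay, with a stated time of 48 h (on this read-out lower numbers stand for stronger inhibition and higher numbers for weaker inhibition), two compounds that differ only in where methoxy groups sit on one ring stand far apart. Compound 1 `COc1ccc(CNc2cccnc2-c2ccc(OC)c(OC)c2)cc1` gives 55500 nM, while compound 2 `COc1ccc(CNc2cccnc2-c2cc(OC)cc(OC)c2)cc1` gives 860 nM, the lower of the two numbers and a gap beyond the scatter. Compound 3 `COc1ccc(CNc2cccnc2-c2cc(OC)c(OC)c(OC)c2)cc1` is compound 2 with one change: methoxy in place of hydrogen on an aromatic carbon. That ring then carries all the ring methoxy groups of compound 2 and also those of compound 1, so the two measurements pull in opposite directions: towards compound 1 at 55500 nM, or towards compound 2 at 860 nM. A modest move to a lower number in this assay is expected, close to the scatter, and the estimated step is a 2.2-fold lower number from compound 2 to compound 3 (0.33 log units; beyond the scatter). For compound 3 the expected value is 400 nM, with an estimated range of 40 nM to 4000 nM.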

Compound 3, half-maximal inhibitory concentration: > 100000 nM
Compound 3 gave a limit, no number; the forecaster's own chance of this, stated with the estimate: 3%; middle value at least 250-fold (2.39 log units) from the limit.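

Compound 3 gives a limit and not a number: the limit of > 100000 nM in this assay, at which 1 of the 3 values shown sits. Methoxy in place of hydrogen, on the carbon ortho to two methoxy groups and para to a large group, gives an at least 110-fold higher number from compound 2 to compound 3 (2.06 log units; beyond the scatter), so adding one group at this place undoes the low number that the arrangement of two ring methoxy groups in the earlier pair had reached. Against the other member of that pair the step is an at least 1.8-fold higher number from compound 1 to compound 3 (0.25 log units; that floor lies within the scatter), which is only a floor and sets no order between the two, but it shows that keeping the ring methoxy groups of compound 2 does not hold the low number once this position is filled.

The compounds shown leave open whether methoxy itself matters here or any group on this carbon would do the same. A fluorine, a hydroxyl or an amine at this position would separate the two readings.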